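This account rests on a few compounds, and the source may have more. Where it says the series, first, only, none or still open, it means among the compounds named here.

Compounds measured in a functional assay on OVCAR-4 cells (Homo sapiens) for inhibition, read by sulforhodamine B assay, with a stated time of 48 h; on this read-out lower numbers stand for stronger inhibition of growth and higher numbers for weaker inhibition of growth:
compound 1 `COc1ccc(-c2[nH]c3ccccc3c2/C=C(\C#N)S(=O)(=O)c2ccccc2)cc1` gives 578 nM
compound 2 `N#C/C(=C\c1c(-c2ccccc2)[nH]c2ccccc12)S(=O)(=O)c1ccccc1` gives 5500 nM

Compound 2 stands at the higher of the two numbers in this assay. Going by the values given here, the only measured step, a 9.5-fold higher number from compound 1 to compound 2 (0.98 log units; beyond the scatter), arises from hydrogen in place of methoxy on an aromatic carbon and lies beyond the scatter.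

Compound 3 `N#C/C(=C\c1c(-c2ccccc2)[nH]c2ccccc12)C(=O)c1ccccc1` differs from compound 2 by benzoyl in place of phenylsulfonyl on a double-bonded chain carbon bound to a double-bonded chain carbon and a triple-bonded carbon. Among the compounds with values here, no measured step touches this part of the molecule; the one step recorded concerns a substituent on the shared core and offers no direct guidance on exchanging phenylsulfonyl for benzoyl. The expectation therefore rests on compound 2 alone, with wide uncertainty, and no direction can be asserted beyond the scatter. Compound 3 is expected to give 5000 nM in this assay, with a range of 1000 nM to 25000 nM, the estimated step being a 1.1-fold lower number from compound 2 to compound 3 (0.04 log units; within the scatter).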

Compound 3, concentration for 50% growth inhibition: 65300 nM
Compound 3: middle estimate off by 13-fold (1.12 log units), on the low side, outside the stated range (above it).
By their numbers in this assay, from the lowest: compound 1; then compound 2; then compound 3.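

In this assay, the place on a double-bonded chain carbon bound to a double-bonded chain carbon and a triple-bonded carbon proves sensitive: benzoyl in place of phenylsulfonyl gives a 12-fold higher number from compound 2 to compound 3 (1.07 log units; beyond the scatter). The earlier step, a 9.5-fold higher number from compound 1 to compound 2 (0.98 log units; beyond the scatter), concerned only methoxy on an aromatic carbon, whereas this one shows that, of these two groups at this place, phenylsulfonyl goes with the stronger inhibition of growth. No measured evidence bearing on the reason for this step is available.

Still open, as far as these compounds go, is whether a carboxylic ester or an amide at this place would stand nearer to compound 2 or to compound 3. Also open, from the compounds shown here alone, is whether methoxy on the aromatic carbon would lower the number when benzoyl is present, as it does with phenylsulfonyl.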